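From Methylpiperidine to Methylpiperazine at the Chain End

The source may report more compounds than this note shows. Statements on the series, on what has been measured and on what is new or still open speak of the compounds shown alone.

Measured compounds:
compound 1, `COc1cc2c(Oc3ccc(NC(=O)c4nn(-c5ccccc5)c(=O)cc4C)cc3F)ccnc2cc1OCCCN1CCN(C)CC1`: 360 nM
compound 2, `COc1cc2c(Oc3ccc(NC(=O)c4nn(-c5ccccc5C(F)(F)F)c(=O)cc4C)cc3F)ccnc2cc1OCCCN1CCCCC1`: 210 nM
compound 3, `COc1cc2c(Oc3ccc(NC(=O)c4nn(-c5ccccc5C(F)(F)F)c(=O)cc4C)cc3F)ccnc2cc1OCCCN1CCC(C)CC1`: 200 nM

In a functional assay on NCI-H460 cells (Homo sapiens) for inhibition, read by MTT assay, with a stated time of 72 h (on this read-out higher numbers stand for weaker inhibition and lower numbers for stronger inhibition), compound 3 gives the lowest of the three numbers, yet it stays within the scatter of compound 2 and of compound 1. Within the data shown here, the only measured single step, a 1.1-fold lower number from compound 2 to compound 3 (0.02 log units; within the scatter), touches the same chain end and lies within the scatter. Compound 4, `COc1cc2c(Oc3ccc(NC(=O)c4nn(-c5ccccc5C(F)(F)F)c(=O)cc4C)cc3F)ccnc2cc1OCCCN1CCN(C)CC1`, carries 4-methylpiperazin-1-yl in place of 4-methylpiperidin-1-yl on a saturated chain carbon, three bonds along the chain from an oxygen on an aromatic ring. Among the measured compounds shown here, no measured pair covers this exact change; compound 1 holds the same 4-methylpiperazin-1-yl end together with a phenyl lacking the trifluoromethyl, and its value sits close to those of compounds 2 and 3. The expected step is therefore one within the scatter: a 1.3-fold higher number from compound 3 to compound 4 (0.10 log units; within the scatter). Compound 4 is estimated at 250 nM, between 110 nM and 600 nM.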

Compound 4, half-maximal inhibitory concentration: 240 nM
Compound 4: middle estimate off by 1.0-fold (0.02 log units), on the high side; low and high end bracket the measured number.
By their numbers in this assay, from the lowest: compounds 3, 2, 4 and 1 (each within the scatter of the next).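

In this assay the change of chain end gives (a 1.2-fold higher number from compound 3 to compound 4 (0.08 log units; within the scatter)) and (a 1.1-fold higher number from compound 2 to compound 4 (0.06 log units; within the scatter)), so at this position 4-methylpiperazin-1-yl cannot be told apart from 4-methylpiperidin-1-yl or piperidin-1-yl. The first measured trifluoromethyl step (a 1.5-fold lower number from compound 1 to compound 4 (0.18 log units; within the scatter)) also stays within the scatter, so that group shows no separable effect on the number with this chain end. No measurement shown explains these results.

On these data alone, whether a morpholin-4-yl end or a longer chain would also stay within the scatter remains open. So does the outcome of a chlorine in place of the trifluoromethyl.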